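From Compound 2 to Compound 4: a Methoxymethyl Removed

The source may hold more compounds than are shown below. What is called first, only, known or untested is meant among the compounds shown, and "the series" means these compounds.

Compound 1 `COc1ccc(C2=C(c3cc(OC)c(OC)c(OC)c3)CC(O[SiH2]C(C)(C)C)C2=O)cc1[N+](=O)[O-]`: > 100 ug/mL, a limit of the assay
Compound 2 `COCOc1cc(C2=C(c3cc(OC)c(OC)c(OC)c3)C(=O)CC2O[SiH2]C(C)(C)C)ccc1OC`: 12 ug/mL
Compound 3 `COc1ccc(C2=C(c3cc(OC)c(OC)c(OC)c3)C(=O)C(O)C2)cc1`: < 1 ug/mL, a limit of the assay

Of the compounds shown here, three have been measured in an ADME assay on HEp-2 cells (Homo sapiens) for cytotoxicity, read by MTT assay, with a stated time of 72 h; on this read-out higher numbers stand for weaker inhibition and lower numbers for stronger inhibition. For compound 1 the read-out is a limit of the assay, > 100 ug/mL. For compound 3 the read-out is also a limit of the assay, < 1 ug/mL. Compound 2 is the only one of the three with a number, giving 12 ug/mL in this assay; the other two values sit at the limit of < 1 ug/mL in this assay, at which 1 of the 3 values shown sits, and at the limit of > 100 ug/mL in this assay, at which 1 of the 3 values shown sits. For the measured compounds named here, no step between two measured compounds differing in one place is available, so nothing is known yet about how a single change moves the number here.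

Compound 4 `COc1ccc(C2=C(c3cc(OC)c(OC)c(OC)c3)C(=O)CC2O[SiH2]C(C)(C)C)cc1O` has not been measured. It differs from compound 2 in one place: hydrogen in place of methoxymethyl on an oxygen on an aromatic ring. For compound 4 in this assay the step that is expected is a 2.4-fold lower number from compound 2 to compound 4 (0.38 log units; beyond the scatter), a move toward a lower number, somewhat beyond the scatter of repeated measurements. Compound 4 is therefore expected to give about 5 ug/mL in this assay, with the estimate ranging from 1 ug/mL to 30 ug/mL.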

Compound 4, half-maximal inhibitory concentration: 14.5 ug/mL
Compound 4: middle estimate off by 2.9-fold (0.46 log units), on the low side, and the stated range covers the measured number.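

In this assay, putting hydrogen in place of methoxymethyl on an oxygen on an aromatic ring gives a 1.2-fold higher number from compound 2 to compound 4 (0.08 log units; within the scatter), the first single-place step available in this series. The two compounds therefore cannot be told apart on this read-out: the change from methoxymethoxy to hydroxy, which takes away 3 heavy atoms and leaves the rest of the structure as it was, does not register at this place on the shared core. Nothing in the data shown speaks to why this exchange leaves the read-out within the scatter.

The compounds shown leave open whether this place tolerates any group on that oxygen or only these two, since a longer chain such as butyl on the oxygen, or an amine standing in place of the hydroxy, might read differently. They also leave open whether the same exchange would read the same way on a core that differs elsewhere, as a single step on one pair of compounds cannot settle that.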